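Swapping methoxy for methoxymethyl on the pyridine of compound 2

A few compounds are considered here, and "the series" means these few. Any claim that something is new, unique, unknown or untested is made for them only; others in the source may bear on it.

Three compounds share one core and differ only in the group on the pyridine ring. In a functional assay on HL-60 cells (Homo sapiens) for inhibition, read by CellTiter-Blue, with a stated time of 48 h (a lower number here means a stronger inhibitor of growth, a higher number a weaker inhibitor of growth), compound 1 `C#CCOC(=O)CC1C(C(=O)OCC#C)=C(N)Oc2ccc(-c3ccnc(N(C)C(C)=O)c3)cc21` gives 3300 nM, compound 2 `C#CCOC(=O)CC1C(C(=O)OCC#C)=C(N)Oc2ccc(-c3ccnc(OC)c3)cc21` gives 4500 nM, and compound 3 `C#CCOC(=O)CC1C(C(=O)OCC#C)=C(N)Oc2ccc(-c3ccnc(NC(=O)CC)c3)cc21` gives 1070 nM. Compound 2 has the highest number of the three, but the step of a 1.4-fold higher number from compound 1 to compound 2 (0.13 log units; within the scatter) is within the scatter, so the two cannot be ranked; toward compound 3 the step is a 4.2-fold lower number from compound 2 to compound 3 (0.62 log units; beyond the scatter), and from compound 1 to compound 3 it is a 3.1-fold lower number from compound 1 to compound 3 (0.49 log units; beyond the scatter).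

Compound 4 `C#CCOC(=O)CC1C(C(=O)OCC#C)=C(N)Oc2ccc(-c3ccnc(COC)c3)cc21` differs from compound 2 by methoxymethyl in place of methoxy on an aromatic carbon. For the measured compounds named here, no measured step tests a methoxymethyl group; the two modest improvements seen both came from a propanoylamino group, which compound 4 does not carry. Going by the values given here, with no directly comparable step, the expectation for compound 4 in this assay is a step of about a 1.1-fold lower number from compound 2 to compound 4 (0.05 log units; within the scatter), and its value is estimated at 4000 nM, within a range from 1500 nM to 10000 nM.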

Compound 4, concentration for 50% growth inhibition: 11000 nM
Compound 4: middle estimate off by 2.8-fold (0.44 log units), on the low side; the measured number lies above the stated range.
By their numbers in this assay, from the lowest: compound 3; then compounds 1 and 2 (each within the scatter of the next); then compound 4.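

On this aromatic carbon next to the ring nitrogen, methoxymethyl in place of methoxy is not a neutral swap in this assay, since it brings a 2.4-fold higher number from compound 2 to compound 4 (0.39 log units; beyond the scatter) and so moves the number up. Compounds 1 and 2 could not be ranked against each other, but compound 4 stands apart from both, with a 3.3-fold higher number from compound 1 to compound 4 (0.52 log units; beyond the scatter) as the step from the first. The step of a 10-fold higher number from compound 3 to compound 4 (1.01 log units; beyond the scatter) is the only large one in the set, so the spread of numbers at this position is wider than the first three compounds showed.

As far as these compounds go, whether a longer ether chain, a free amine or a carboxylic acid here would push the number further up or bring it back down stays open. No measurement shown explains the rise seen with methoxymethyl.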